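The source may report more compounds than this note shows. Statements on the series, on what has been measured and on what is new or still open speak of the compounds shown alone.

The three measured compounds share one core and differ only in the group on the aromatic ring that carries the amide nitrogen. Compound 1 `CC(C)c1sc(N2CCN(C)CC2)nc1C(=O)Nc1ccccc1Cl` bears chloro, compound 2 `CC(C)c1sc(N2CCN(C)CC2)nc1C(=O)Nc1ccccc1C(F)(F)F` trifluoromethyl and compound 3 `CC(C)c1sc(N2CCN(C)CC2)nc1C(=O)Nc1ccccc1C#N` cyano. In an ADME assay on HepG2 cells (Homo sapiens) for inhibition (a higher number here means a weaker inhibitor, a lower number a stronger inhibitor), compound 1 reaches only the limit of the assay, > 100000 nM. In this assay compound 2 gives 50000 nM and compound 3 gives 32000 nM. Compound 3 therefore holds the lowest of the two numbers shown, and the nearest value sits within the scatter, a 1.6-fold lower number from compound 2 to compound 3 (0.19 log units; within the scatter). Measured from compound 1 the steps are an at least 2.0-fold lower number from compound 1 to compound 2 (0.30 log units; that floor lies within the scatter) and an at least 3.1-fold lower number from compound 1 to compound 3 (0.49 log units; beyond the scatter). Compound 4 `CC(C)c1sc(N2CCN(C)CC2)nc1C(=O)Nc1ccccc1OC(F)(F)F` is not yet measured and differs from compound 3 by trifluoromethoxy in place of cyano on an aromatic carbon. For the measured compounds named here, the steps that bear on this change, a 1.6-fold lower number from compound 2 to compound 3 (0.19 log units; within the scatter), an at least 2.0-fold lower number from compound 1 to compound 2 (0.30 log units; that floor lies within the scatter) and an at least 3.1-fold lower number from compound 1 to compound 3 (0.49 log units; beyond the scatter), all lie at or close to the scatter. Compound 4 is therefore expected to shift only a little, a 1.4-fold higher number from compound 3 to compound 4 (0.15 log units; within the scatter), toward a weaker number. Compound 4 is estimated at 45000 nM in this assay, within a range from 20000 nM to 100000 nM.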

Compound 4, half-maximal inhibitory concentration: > 100000 nM
Compound 4 was reported as a limit; the forecaster's own chance of this, stated with the estimate: 25%; at least 2.2-fold (0.34 log units) between middle value and limit.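

For the compounds shown here, at this position, on an aromatic carbon ortho to a large group, the earlier compounds left only cyano and trifluoromethyl within the scatter of each other, whereas trifluoromethoxy in place of cyano gives a clear shift in this assay, an at least 3.1-fold higher number from compound 3 to compound 4 (0.49 log units; beyond the scatter). Trifluoromethoxy in place of trifluoromethyl points the same way, an at least 2.0-fold higher number from compound 2 to compound 4 (0.30 log units; that floor lies within the scatter), but that step is less firm. The step from chloro to trifluoromethoxy cannot be read, and of the four groups only cyano and trifluoromethyl now give numbers short of the assay's ceiling: the limit of > 100000 nM in this assay, at which 2 of the 4 values shown sit.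

The compounds shown leave open whether an amine, a carboxylic acid or a longer chain such as ethoxy at this position would give a readable number in this assay. They also leave open how far apart the two compounds at the limit truly lie.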